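The compounds below may be only part of what the source reports. "The series", "measured", "known", "first", "only" and "open" are said of these compounds alone.

Compound 1 `CCOC(=O)C1=C(Nc2ccc(F)cc2)S/C(=C\c2ccc[nH]2)C1=O` gives 15900 nM in a functional assay on JAR cells (Homo sapiens) for inhibition, read by MTT assay, with a stated time of 72 h; on this read-out higher numbers stand for weaker inhibition and lower numbers for stronger inhibition.
Compound 2 `CCOC(=O)C1=C(Nc2ccc(C(F)(F)F)cc2)S/C(=C\c2ccc[nH]2)C1=O` gives 46800 nM in this assay.

Compound 1 stands lowest of the two numbers in this assay; its nearest neighbour is compound 2, separated by a 2.9-fold higher number from compound 1 to compound 2 (0.47 log units; beyond the scatter). The unmeasured compound 3 `CCOC(=O)C1=C(Nc2cccc([N+](=O)[O-])c2)S/C(=C\c2ccc[nH]2)C1=O` differs from compound 1 in a single place: 3-nitrophenyl in place of 4-fluorophenyl on an amine nitrogen. Within the data shown here, only one measured step bears on this change, a 2.9-fold higher number from compound 1 to compound 2 (0.47 log units; beyond the scatter), in which trifluoromethyl replaced fluoro on an aromatic carbon and the number rose beyond the scatter. Compound 3 again alters the group carried on the amine nitrogen of the shared core, so a modest rise of roughly that size, or a step that stays within the scatter, is expected in this assay. Compound 3 is therefore estimated at 25000 nM, with a range from 8000 nM to 80000 nM. This estimate is expected to correspond to a 1.6-fold higher number from compound 1 to compound 3 (0.20 log units; within the scatter).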

Compound 3, half-maximal inhibitory concentration: 10100 nM
Estimate against measurement, compound 3: 2.5-fold (0.39 log units) above, within the range that was stated.
By their numbers in this assay, from the lowest: compounds 3 and 1 (each within the scatter of the next); then compound 2.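

In this assay, replacing 4-fluorophenyl with 3-nitrophenyl on the amine nitrogen gives a 1.6-fold lower number from compound 1 to compound 3 (0.20 log units; within the scatter), so this exchange of the whole aryl group produces no readable change. The earlier step, a 2.9-fold higher number from compound 1 to compound 2 (0.47 log units; beyond the scatter), had shown only a rise beyond the scatter, whereas this result shows that not every change to the group on this nitrogen moves the number that far. Nothing available here accounts for the difference between these two steps.

The compounds shown leave open whether a phenyl group carrying an amine or a carboxylic acid would shift the number beyond the scatter in either direction. They also leave open what a simple alkyl chain on the amine nitrogen, in place of the aromatic ring, would do in this assay.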